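This account rests on a few compounds, and the source may have more. Where it says the series, first, only, none or still open, it means among the compounds named here.

Measured in a functional assay (blood) for inhibition, with Homo sapiens as the target; on this read-out higher numbers stand for weaker inhibition and lower numbers for stronger inhibition:
compound 1 `CO/N=C(\C)c1ccc(Sc2cc(F)cc(C3CCOCC3)c2)cc1` gives 110 nM;
compound 2 `CN(C)/C(=N\O)c1ccc(Sc2cc(F)cc(C3CCOCC3)c2)cc1` gives 280 nM;
compound 3 `CS/C(=N\O)c1ccc(Sc2cc(F)cc(C3CCOCC3)c2)cc1` gives 190 nM.

Compound 3 stands second highest of these three numbers, and both of its gaps lie within the usual scatter: a 1.5-fold lower number from compound 2 to compound 3 (0.17 log units; within the scatter) and a 1.7-fold higher number from compound 1 to compound 3 (0.24 log units; within the scatter). Compound 4 `CC(=O)/C(=N\O)c1ccc(Sc2cc(F)cc(C3CCOCC3)c2)cc1` differs from compound 3 by one change: acetyl in place of methylsulfanyl on a carbon with a double bond to nitrogen. Going by the values given here, every measured step so far swaps the group on this same carbon, and each was small: a 2.5-fold higher number from compound 1 to compound 2 (0.41 log units; beyond the scatter), a 1.7-fold higher number from compound 1 to compound 3 (0.24 log units; within the scatter), a 1.5-fold lower number from compound 2 to compound 3 (0.17 log units; within the scatter). By that record a further swap at this place is expected to move this assay little, in no certain direction, likely not beyond the scatter. Compound 4 is therefore estimated at 200 nM, in a range from 80 nM to 500 nM, which means an expected 1.1-fold higher number from compound 3 to compound 4 (0.02 log units; within the scatter).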

Compound 4, half-maximal inhibitory concentration: 850 nM
Compound 4: middle estimate off by 4.3-fold (0.63 log units), on the low side, outside the stated range (above it).
By their numbers in this assay, from the lowest: compounds 1, 3 and 2 (each within the scatter of the next, the first and the last beyond it); then compound 4.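

Acetyl on this carbon, the one with a double bond to nitrogen, shifts this assay more than any earlier swap did: (a 4.5-fold higher number from compound 3 to compound 4 (0.65 log units; beyond the scatter)), (a 3.0-fold higher number from compound 2 to compound 4 (0.48 log units; beyond the scatter)) and (a 7.7-fold higher number from compound 1 to compound 4 (0.89 log units; beyond the scatter)). The position is therefore less forgiving than the earlier small steps suggested, since at least one group here raises the number well beyond the scatter. Nothing available explains why acetyl behaves this way.

As far as these compounds go, whether the carbonyl of acetyl matters remains open. A carboxylic acid, an amide or a longer chain of carbons on this carbon could show whether other groups follow acetyl or stay close to methylsulfanyl.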